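The source may report more compounds than this note shows. Statements on the series, on what has been measured and on what is new or still open speak of the compounds shown alone.

Measured so far:
compound 1 `Nc1nc(-c2ccco2)nc2sc(CN3CC=CCC3)cc12` gives 150 nM
compound 2 `N#Cc1cccc(-c2nc(N)c3cc(CN4CC=CC4)sc3n2)c1` gives 2070 nM

Both numbers come from an assay on CHO-K1 cells for antagonist activity at adenosine receptor A1 (Homo sapiens), read by a beta-galactosidase reporter, with stated times of 15 min and 6 h; a higher number here means a weaker inhibitor, a lower number a stronger inhibitor. Compound 2 has the higher of the two numbers, with compound 1 showing a lower value in this assay, and that gap is beyond the usual scatter. For the measured compounds named here, the two compounds differ in more than one place, so no single step between them is counted.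

Compound 3 `N#Cc1cccc(-c2nc(N)c3cc(CN4CC=CCC4)sc3n2)c1` has not been measured in this assay. It differs from compound 2 only in a group of 6 heavy atoms (5 carbon, 1 nitrogen; one six-membered non-aromatic ring with 1 hetero atom) in place of a group of 5 heavy atoms (4 carbon, 1 nitrogen; one five-membered non-aromatic ring with 1 hetero atom), on a saturated chain carbon bound to an aromatic carbon. Going by the values given here, no measured pair isolates this change. Compound 1 carries the same six-membered ring as compound 3 and sits lower than compound 2, but it also carries a different aryl group, so its number is not a clean guide. The step from compound 2 to compound 3 is expected to be modest, toward a lower number, as a 2.1-fold lower number from compound 2 to compound 3 (0.32 log units; beyond the scatter). Compound 3 is estimated at 1000 nM, with a range of 300 nM to 4000 nM.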

Compound 3, inhibition constant: 210 nM
The estimate for compound 3 lay 4.8-fold (0.68 log units) above the measured number; the whole stated range lies above it.
By their numbers in this assay, from the lowest: compounds 1 and 3 (each within the scatter of the next); then compound 2.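

In this assay, the group on the saturated chain carbon bound to an aromatic carbon now has a clean comparison: the six-membered ring in place of the five-membered ring gives a 9.9-fold lower number from compound 2 to compound 3 (0.99 log units; beyond the scatter), so ring size at this position counts when the 3-cyanophenyl group is held fixed. With the six-membered ring held fixed, 3-cyanophenyl in place of furan-2-yl on an aromatic carbon gives a 1.4-fold higher number from compound 1 to compound 3 (0.15 log units; within the scatter), so this aryl exchange does not separate the two compounds. Nothing measured here accounts for either step.

The compounds shown leave open whether the ring-size step carries over when furan-2-yl is the aryl group. They also leave open how piperidine, morpholine or an open-chain amine such as diethylamine would compare on the same chain carbon.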